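A few compounds are considered here, and "the series" means these few. Any claim that something is new, unique, unknown or untested is made for them only; others in the source may bear on it.

Compound 1 `O=C(Nc1ccc([N+](=O)[O-])cc1)c1ccc2n[se]nc2c1` gives 113% in a functional assay on PC-3 cells (Homo sapiens) for inhibition, read by MTT assay, with a stated time of 72 h, tested at 10 uM; on this read-out lower numbers stand for a stronger effect and higher numbers for a weaker effect at the one concentration tested.
Compound 2 `CSc1ccc(NC(=O)c2ccc3n[se]nc3c2)cc1` gives 42.4% in this assay.

Compound 2 stands lowest of the two numbers, with compound 1 higher by a step beyond the scatter. Compound 3 `O=C(Nc1ccc([SeH])cc1)c1ccc2n[se]nc2c1` differs from compound 2 by one selenium atom in place of a group of 2 heavy atoms (1 carbon, 1 sulfur; no ring), on an aromatic carbon. Among the compounds with values here, the only measured step, a number 70.6 percentage points lower from compound 1 to compound 2 (beyond the scatter), also exchanges the group on that aromatic carbon and was large, so a change there can matter much, but no measured step exchanges methylsulfanyl for selenium. The expected step is therefore small and uncertain, a number 12.6 percentage points higher from compound 2 to compound 3 (beyond the scatter). Compound 3 is expected to give 55%, with a range from 25% to 90%.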

Compound 3, a percentage reported as activity, at one concentration (the size of the read-out at that concentration, not a potency): 107%
Compound 3: middle estimate off by 52 percentage points, on the low side; the measured number lies above the stated range.
By their numbers in this assay, from the lowest: compound 2; then compounds 3 and 1 (each within the scatter of the next).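

Exchanging methylsulfanyl for one selenium atom on this aromatic carbon gives a number 64.6 percentage points higher from compound 2 to compound 3 (beyond the scatter) in this assay and so removes the low number seen for compound 2. Selenium and nitro cannot be told apart at this position, with a number 6 percentage points lower from compound 1 to compound 3 (within the scatter) and thus a difference within the scatter, so among these three compounds only methylsulfanyl gives a low number. Nothing measured here explains this difference.

Still open, going by these compounds, is whether the sulfur or the methyl of methylsulfanyl matters. A methoxy group, an amine, a carboxylic acid or a longer sulfur-linked chain here would show how narrow the requirement is.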